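The compounds below may be only part of what the source reports. "The series", "measured", "known", "first", "only" and "open" are said of these compounds alone.

Measured so far:

compound 1, `CC(C)N1C(=O)COc2ccc(-c3cccc(NS(=O)(=O)c4ccc(F)cc4)c3)cc21`. In a functional assay on HepG2 cells (Homo sapiens) for antiproliferative activity, read by MTT assay, with a stated time of 72 h (a higher number here means a weaker inhibitor, a lower number a stronger inhibitor), compound 1 reaches only the assay limit, > 40000 nM.
compound 2, `O=C1COc2ccc(-c3cccc(NS(=O)(=O)c4ccc(F)cc4)c3)cc2N1c1ccc(Cl)cc1`. In this assay compound 2 gives 27800 nM.
compound 3, `COc1ncc(-c2ccc3c(c2)N(c2ccc(Cl)cc2)C(=O)CO3)cc1NS(=O)(=O)c1ccc(F)cc1`. In this assay compound 3 gives 17900 nM.

Compound 2 and compound 3 are built on different cores; the difference between the two cores is not broken down here. Compound 3 has the lower of the two numbers, but the gap to compound 2 lies within the scatter, so no order is read from it.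

Compound 1 and compound 2 share a core and differ in one place: isopropyl in place of 4-chlorophenyl on an amide-type nitrogen in a ring. This change gives an at least 1.4-fold higher number from compound 2 to compound 1 (0.15 log units; that floor lies within the scatter). Only a floor can be stated for that step, since compound 1 sits at the limit of > 40000 nM in this assay, at which 1 of the 3 values shown sits.

Compound 4, `COc1ncc(-c2ccc3c(c2)N(C(C)C)C(=O)CO3)cc1NS(=O)(=O)c1ccc(F)cc1`, is not yet measured in this assay. It stands to compound 3 as compound 1 stands to compound 2: isopropyl in place of 4-chlorophenyl on an amide-type nitrogen in a ring. The place is described in the same words for both pairs, so the change is the same one. Only one earlier case of it exists, and that case ends at a limit, so the expectation rests on a single floor. The step is expected to be a 2.2-fold higher number from compound 3 to compound 4 (0.35 log units; beyond the scatter), weakening compound 4 against compound 3 by at least as much as an at least 1.4-fold higher number from compound 2 to compound 1 (0.15 log units; that floor lies within the scatter). Compound 4 is therefore estimated at 40000 nM, with a range from 18000 nM to 120000 nM and a real chance that only a limit is reported.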

Compound 4, half-maximal inhibitory concentration: 37200 nM
For compound 4 the middle estimate is 1.1-fold (0.03 log units) above the measured one, and the stated range covers the measured number.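

On the core of compound 3, isopropyl in place of 4-chlorophenyl on an amide-type nitrogen in a ring gives a 2.1-fold higher number from compound 3 to compound 4 (0.32 log units; beyond the scatter) in this assay. On the core of compound 1 the same change can be read only as a floor, so nothing there goes against the step on the core of compound 3, but whether the step has the same size on both cores remains unsettled: the same change on two cores in this assay, an at least 1.4-fold higher number (0.15 log units; that floor lies within the scatter) from compound 2 to compound 1 and a 2.1-fold higher number (0.32 log units; beyond the scatter) from compound 3 to compound 4; the limit leaves it open whether they differ

The series therefore offers one measured step and one floor, which is compatible with the change carrying from one core to the other but does not demonstrate it, and the floor rests on the reading for compound 1, which is a limit and not a number: the limit of > 40000 nM in this assay, at which 1 of the 4 values shown sits.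

Only 4-chlorophenyl and isopropyl appear at this nitrogen among the compounds shown, so it remains open how a longer chain, an amine or a carboxylic acid at that place would read in this assay. Going by these compounds, it is also open whether the change behaves alike on any core beyond these two, since each core supplies a single pair.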